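The compounds below may be only part of what the source reports. "The series", "measured", "known", "first", "only" and "open" are said of these compounds alone.

Working notes on the series, read in an ADME assay on a cell-free system (plasma, Homo sapiens) (on this read-out higher numbers stand for a larger free fraction and lower numbers for a smaller free fraction), throughout. In this assay compound 1 (`Cc1ccc(S(=O)(=O)N2CCCCC2C)cc1C#Cc1cc(Cl)ccc1OCC(=O)O`) carries no number, its entry being "not determined" (no result reported) only. Among the compounds with values here, compound 2 (`CS(=O)(=O)c1ccc(F)c(C#Cc2cc(Cl)ccc2OCC(=O)O)c1`) gives 0.013 as the sole number available, so its standing cannot be ranked against any other compound. Next in line is compound 3 (`Cc1ccc(S(C)(=O)=O)cc1C#Cc1cc(Cl)ccc1OCC(=O)O`), not yet measured. The structural change is methyl in place of fluoro on an aromatic carbon, ortho to a large group and para to a methylsulfonyl group. Within the data shown here, the series offers no measured pair differing in one place, so no observed step is available for calibration. For a swap of one single heavy atom for another, with no net charge involved, no step beyond the scatter is expected in this assay, with at most a slight lean toward a smaller free fraction. The expected move is a 1.2-fold lower number from compound 2 to compound 3 (0.07 log units; within the scatter) in size. The anchor for this expectation is compound 2 at 0.013 alone. Compound 3 is estimated at 0.011 in this assay, within an expected range of 0.006 to 0.022 for repeated measurements.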

Compound 3, unbound fraction: 0.017
Beside the measured number, compound 3's estimate is 1.5-fold (0.19 log units) below it; the measured number falls inside the stated range.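

Methyl in place of fluoro on an aromatic carbon, ortho to a large group and para to a methylsulfonyl group, now has its first measured reading in this assay: a 1.3-fold higher number from compound 2 to compound 3 (0.12 log units; within the scatter). At this position, the read-out does not tell the two single-heavy-atom groups apart, so compound 2 and compound 3 count as equal in this assay within the usual scatter of repeated measurements; this finding rests on one pair and holds for this exchange only. No measured information on the compounds accounts for this result.

Any step involving compound 1 cannot be read, so the series still has no second reference for the size of a change in this assay. On these data alone, whether an amine, a nitrile or a longer chain on this same aromatic carbon would give a step beyond the scatter remains open, as does whether the equivalence of fluoro and methyl would hold with a group other than methylsulfonyl in the para position.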